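The compounds below may be only part of what the source reports. "The series", "measured", "known", "first", "only" and "open" are said of these compounds alone.

In a functional assay on microsomes for inhibition, with a stated time of 1 h (a higher number here means a weaker inhibitor, a lower number a stronger inhibitor), compound 1 `CCOC(=O)c1cnn(-c2nc(-c3ccc(N(C)C)cc3)c(C#N)c(=O)n2C)c1N` gives 111 ug/mL. Compound 2 `Cn1c(NN)nc(-c2ccco2)c(C#N)c1=O` gives 78 ug/mL, and compound 3 `CSc1nc(-c2ccc(N(C)C)cc2)c(C#N)c(=O)n1C` gives 98 ug/mL. All three numbers lie within the usual scatter of one another, so compound 1 stands level with the other two and the set supports no ranking. For the measured compounds named here, no two measured compounds differ in one place only, which leaves no measured step to guide the next comparison. Compound 1 and compound 3 share the 4-(dimethylamino)phenyl group, and compound 2 lacks it, yet its value still falls within the scatter of theirs.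

Compound 4 `CCOC(=O)c1cnn(-c2nc(-c3ccc(Cl)cc3)c(C#N)c(=O)n2C)c1N` follows from compound 1 with chloro in place of dimethylamino on an aromatic carbon, para to a large group: chloro in place of dimethylamino on an aromatic carbon. The same difference, cut one bond further out, reads 4-(dimethylamino)phenyl to 4-chlorophenyl. The measured compounds offer no direct evidence on this exchange in this assay, so the expectation rests on the close agreement of the three values and points to no shift beyond the scatter. The expected step is a 1.2-fold lower number from compound 1 to compound 4 (0.07 log units; within the scatter), with no firm direction. For compound 4, the estimated value is 95 ug/mL, with an expected range of 45 ug/mL to 200 ug/mL.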

Compound 4, half-maximal inhibitory concentration: 88 ug/mL
For compound 4 the middle estimate is 1.1-fold (0.03 log units) above the measured one; the range from low to high includes it.
By their numbers in this assay, from the lowest: compounds 2, 4, 3 and 1 (each within the scatter of the next).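

In this assay the series now holds its first step between compounds that differ in one place, and it reads a 1.3-fold lower number from compound 1 to compound 4 (0.10 log units; within the scatter) for chloro in place of dimethylamino on an aromatic carbon, para to a large group. At this position, then, 4-(dimethylamino)phenyl can give way to 4-chlorophenyl, with 3 heavy atoms leaving, 1 entering and the hydrogen-bond acceptor of dimethylamino gone, and the number stays within the scatter, so on this one pair the dimethylamino group is not needed for a value in this range. No measured data bear on why this exchange leaves the number level.

Still open, as far as these compounds go, is whether any group at this position can move the number beyond the scatter, as one exchange between two close values sets no trend, and a carboxylic acid, a primary amine or a methoxy group on the same aromatic carbon would test this. Also open, from the compounds shown here alone, is whether chloro in place of dimethylamino reads the same way on compound 3, where the rest of the molecule differs from compound 1.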